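Thiocarbonyl amine swap: from chloroindoline to 4-methylpiperidine

This account rests on a few compounds, and the source may have more. Where it says the series, first, only, none or still open, it means among the compounds named here.

Measured so far:
compound 1 `Nc1ccccc1NC(=O)c1ccc(CSC(=S)N2CCN(C(c3ccccc3)c3ccccc3)CC2)cc1`: 9.8%
compound 2 `Nc1ccccc1NC(=O)c1ccc(CSC(=S)N2CCCc3ccccc32)cc1`: 38.5%
compound 3 `Nc1ccccc1NC(=O)c1ccc(CSC(=S)N2CCc3cc(Cl)ccc32)cc1`: 57.7%

In a functional assay on MGC-803 cells (Homo sapiens) for antiproliferative activity, read by CCK-8 assay, with a stated time of 72 h, tested at 2 uM (on this read-out lower numbers stand for a weaker effect and higher numbers for a stronger effect at the one concentration tested), compound 3 stands highest of the three numbers, and compound 2 comes nearest to it. Within the data shown here, the only single-place step measured is a number 19.2 percentage points higher from compound 2 to compound 3 (beyond the scatter), a change of one ring amine for another on the thiocarbonyl carbon. Compound 4 `CC1CCN(C(=S)SCc2ccc(C(=O)Nc3ccccc3N)cc2)CC1` carries a further change at that position: 4-methylpiperidin-1-yl in place of 5-chloro-2,3-dihydro-1H-indol-1-yl on a thiocarbonyl carbon. Among the measured compounds shown here, no measured step exchanges a fused amine for a plain saturated one, so the size of this step is uncertain. Compound 1, whose thiocarbonyl carbon also bears a saturated ring amine, gives 9.8%. On this basis compound 4 is expected to fall below compound 3, with a downward step of a number 22.7 percentage points lower from compound 3 to compound 4 (beyond the scatter), and an estimated value of 35% in the range 15% to 55%.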

Compound 4, a percentage reported as inhibition, at one concentration (the size of the read-out at that concentration, not a potency): 28.1%
Compound 4: the middle estimate sits 6.9 percentage points above what was measured, and the stated range covers the measured number.
By their numbers in this assay, from the lowest: compound 1; then compound 4; then compound 2; then compound 3.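

In this assay, among these compounds, this is the first measured exchange of a fused ring amine for a plain saturated one on the thiocarbonyl carbon, and 4-methylpiperidin-1-yl lowers the read-out against both fused amines: a number 29.6 percentage points lower from compound 3 to compound 4 (beyond the scatter) and a number 10.4 percentage points lower from compound 2 to compound 4 (beyond the scatter), each beyond the scatter. At this position, then, compound 2 and compound 3 both stand above compound 4, so the result depends on more than the choice between the two fused amines. Nothing shown here gives a reason for these steps.

From the compounds shown here alone, what remains open is how a piperidine without the methyl group or a morpholine would stand at this position. Going by these compounds, it is also open how an indoline without the chlorine would compare.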